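This account rests on a few compounds, and the source may have more. Where it says the series, first, only, none or still open, it means among the compounds named here.

Measured so far, in a functional assay on DU-145 cells (Homo sapiens) for cytotoxicity, read by MTT assay, with a stated time of 48 h; a lower number here means a stronger inhibitor, a higher number a weaker inhibitor:

- compound 1 `COc1cc(/C=C2\C(=O)Nc3ccccc32)ccc1OCCCN1CCN(c2ccccn2)CC1`: > 20000 nM, a limit of the assay rather than a number
- compound 2 `COc1cc(/C=C2\C(=O)Nc3ccc(Cl)cc32)ccc1OCCCN1CCN(c2ccccn2)CC1`: > 20000 nM, again a limit rather than a number
- compound 3 `COc1cc(/C=C2\C(=O)Nc3ccccc32)ccc1OCCCN1CCN(c2ncccc2C(F)(F)F)CC1`: > 20000 nM, again a limit rather than a number

Compound 3 therefore stands at the edge of what this assay can read, and it is not alone there: all three values sit at the same limit, (the limit of > 20000 nM in this assay, at which 3 of the 3 values shown sit), so none of the three compounds can be ranked against the others.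

Compound 4 `COc1cc(/C=C2\C(=O)Nc3ccc(Cl)cc32)ccc1OCCCN1CCN(c2ncccc2C(F)(F)F)CC1` keeps the shared core of compound 3 and differs from it in one place: chloro in place of hydrogen on an aromatic carbon.

The same exchange has been made once before on a different background, the step that the two limits leave unreadable from compound 1 to compound 2, and both of its end points are limits, so its size cannot be read. The step that the two limits leave unreadable from compound 1 to compound 3, which brings in the trifluoromethyl group that compound 4 also carries, is just as unreadable for the same reason. Within the data shown here, no measured step therefore points to a change beyond the scatter in either direction, and the expected step that the limit leaves unreadable from compound 3 to compound 4 is one that the limit is likely to leave unreadable again. Compound 4 is expected to give 40000 nM, within 15000 nM to 200000 nM.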

Compound 4, half-maximal inhibitory concentration: 1610 nM
Beside the measured number, compound 4's estimate is 25-fold (1.40 log units) above it; measured number below the stated range.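

In this assay, placing chloro on the aromatic carbon that is meta to a fused ring and para to a fused ring gives an at least 12-fold lower number from compound 3 to compound 4 (1.09 log units; beyond the scatter), so this position on the carbon-only aromatic ring can carry a change large enough to bring a compound within the range the assay can read. The pyridine-side change tells the same story from the other direction, since trifluoromethyl in place of hydrogen on an aromatic carbon gives an at least 12-fold lower number from compound 2 to compound 4 (1.09 log units; beyond the scatter). The steps from compound 1 cannot be read, and compound 4, the one compound here that carries both chloro and trifluoromethyl, is the only one not left at a limit rather than a number: the limit of > 20000 nM in this assay, at which 3 of the 4 values shown sit.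

How much either group contributes without the other stays unknown, so the compounds shown cannot separate a true dependence of one group on the other from a gain hidden behind the limit. Also open, from the compounds shown here alone, is whether a fluoro, a bromo or a methoxy group on the same aromatic carbon, or a nitrile in place of trifluoromethyl, would give a readable number as well.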